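Methoxycarbonyl removal from compound 1

A few compounds are considered here, and "the series" means these few. Any claim that something is new, unique, unknown or untested is made for them only; others in the source may bear on it.

Measured so far:
- compound 1 `COC(=O)c1ccc2ccc(C(=O)N(C)C)c-2cc1`: 50 ug/mL
- compound 2 `COC(=O)c1ccc2ccc(C(=O)c3ccccc3)c-2cc1`: < 1 ug/mL, a limit of the assay

For the measured compounds named here, in a physicochemical assay for solubility, with a stated time of 24 h, at pH 4.5 (a lower number here means a less soluble compound, a higher number a more soluble compound), compound 1 gives 50 ug/mL, the only actual number. The one other result is the limit of < 1 ug/mL in this assay, at which 1 of the 2 values shown sits. Compound 2 is reported only as a limit, < 1 ug/mL.

Compound 3 `CN(C)C(=O)c1ccc2cccccc1-2` is not yet measured. It differs from compound 1 by hydrogen in place of methoxycarbonyl on an aromatic carbon.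

Going by the values given here, the single measured step is an at least 50-fold lower number from compound 1 to compound 2 (1.69 log units; beyond the scatter). That step is large, but it is phenyl in place of dimethylamino on a carbonyl carbon, a change that compound 3 does not share. Among the compounds with values here, no measured step covers the loss of methoxycarbonyl, so the size of this change rests on no direct evidence. The expectation therefore stays close to compound 1 at 50 ug/mL, with no step beyond the scatter and no firm direction.

The expected step is a 1.2-fold higher number from compound 1 to compound 3 (0.08 log units; within the scatter). For compound 3 the estimate is 60 ug/mL, with an expected range of 15 ug/mL to 250 ug/mL.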

Compound 3, solubility: > 44 ug/mL
Compound 3: no number, only a limit; the forecaster's own chance of this, stated with the estimate: 5%; the middle value is on the limit's open side.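

In this assay compound 3 is reported only as a limit, > 44 ug/mL. The step from compound 1 to compound 3 cannot be read, so this result gives no new step size or direction. The compounds shown leave open how hydrogen in place of methoxycarbonyl on an aromatic carbon moves the number in this assay.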